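A few compounds are considered here, and "the series" means these few. Any claim that something is new, unique, unknown or untested is made for them only; others in the source may bear on it.

Measured so far:
- compound 1, `CC(C)=CCC/C(C)=C/COc1ccc(C2CC2C(=O)NNC(=O)c2ccncc2)cc1`: 78000 nM
- compound 2, `O=C(NNc1nncc2ccccc12)C1CC1c1ccc(OCC(F)(F)F)cc1`: 48000 nM

Both numbers come from a functional assay on A549 cells (Homo sapiens) for inhibition, read by MTT assay, with a stated time of 72 h; a higher number here means a weaker inhibitor, a lower number a stronger inhibitor. Compound 1 holds the higher of the two numbers in this assay, but the gap to compound 2 lies within the usual scatter, so nothing separates the two beyond repeat-to-repeat variation. Both cores share the cyclopropane-carbohydrazide arrangement; the ether chain on the phenyl ring differs between them.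

The next compound to be measured is compound 3, `CC(C)=CCOc1ccc(C2CC2C(=O)NNC(=O)c2ccncc2)cc1`. It departs from compound 1 in one place: hydrogen in place of 3-methylbut-2-en-1-yl on a saturated chain carbon bound to a double-bonded chain carbon. Within the data shown here, no step between measured compounds is available for this change, so there is nothing to anchor its size. With both measured values sitting close together and high, the expectation is for no step beyond the scatter, a step from compound 1 of a 1.0-fold higher number from compound 1 to compound 3 (0.01 log units; within the scatter) being the estimate. Compound 3 is therefore expected to give 80000 nM in this assay, within a range from 30000 nM to 200000 nM.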

Compound 3, half-maximal inhibitory concentration: > 100000 nM
Compound 3: a limit, no number; the forecaster's own chance of this, stated with the estimate: 25%; middle value at least 1.2-fold (0.09 log units) away from the limit.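

Compound 3 gives > 100000 nM in this assay, and this value is a limit of the assay, not a number. Hydrogen in place of 3-methylbut-2-en-1-yl on a saturated chain carbon bound to a double-bonded chain carbon gives an at least 1.2-fold higher number from compound 1 to compound 3 (0.10 log units; that floor lies within the scatter), so going from 3,7-dimethylocta-2,6-dien-1-yl to 3-methylbut-2-en-1-yl does not bring the number down. The reading of this step ends at the top of the range of this assay: the limit of > 100000 nM in this assay, at which 1 of the 3 values shown sits.

The true size of the step cannot be read, and with a floor inside the scatter, the two chains are not firmly separated. Also open, on these data alone, is whether an amine or a carboxylic acid in place of 3-methylbut-2-en-1-yl on that saturated chain carbon would give a lower number in this assay.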